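This account rests on a few compounds, and the source may have more. Where it says the series, first, only, none or still open, it means among the compounds named here.

Compound 1 `Cc1ccc(S(=O)(=O)N2C/C(=C\c3cccnc3)C(=O)/C(=C/c3ccccc3C(F)(F)F)C2)cc1`: 12300 nM
Compound 2 `O=C1/C(=C/c2cccnc2)CN(S(=O)(=O)c2ccc(C(F)(F)F)cc2)C/C1=C\c1ccccc1C(F)(F)F`: 14300 nM

In an ADME assay on L02 cells (Homo sapiens) for cytotoxicity, read by MTT assay, with a stated time of 24 h (on this read-out higher numbers stand for weaker inhibition and lower numbers for stronger inhibition), compound 2 gives 14300 nM, level with compound 1 within the scatter. Compound 3 `O=C1/C(=C/c2cccnc2)CN(S(=O)(=O)c2ccc(F)cc2)C/C1=C\c1ccccc1C(F)(F)F` differs from compound 2 by one change: fluoro in place of trifluoromethyl on an aromatic carbon. Among the measured compounds shown here, one measured step bears on this: a 1.2-fold higher number from compound 1 to compound 2 (0.07 log units; within the scatter), which also involves trifluoromethyl on an aromatic carbon, there in place of methyl. That step stayed within the scatter, so no step beyond the scatter is expected here. The estimated change is a 1.1-fold lower number from compound 2 to compound 3 (0.04 log units; within the scatter). Compound 3 is expected at 13000 nM, with an estimated range of 8000 nM to 21000 nM.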

Compound 3, half-maximal inhibitory concentration: 16100 nM
Estimate against measurement, compound 3: 1.2-fold (0.09 log units) below, and the stated range covers the measured number.
By their numbers in this assay, from the lowest: compounds 1, 2 and 3 (each within the scatter of the next).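

Compound 3 adds fluoro as a third group on this aromatic carbon, after methyl and trifluoromethyl. In this assay the steps of a 1.1-fold higher number from compound 2 to compound 3 (0.05 log units; within the scatter) and a 1.3-fold higher number from compound 1 to compound 3 (0.12 log units; within the scatter) both lie within the scatter, so these three groups cannot be told apart here, even though trifluoromethyl has four heavy atoms and fluoro one. Nothing available accounts for this flat result. As far as these compounds go, whether an amine or a carboxylic acid at this carbon would move the number remains open, as does whether the flatness holds with other groups elsewhere on the core.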